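This account rests on a few compounds, and the source may have more. Where it says the series, first, only, none or still open, it means among the compounds named here.

Working notes on the anilide series

Within the data shown here, compound 3 `O=C(CN1CCN(c2nnc(Cc3ccccc3)c3ccccc23)CC1)Nc1c(F)cccc1F` gives 19700 nM in a functional assay on HT-29 cells (Homo sapiens) for cytotoxicity, read by MTT assay, with a stated time of 72 h (on this read-out higher numbers stand for weaker inhibition and lower numbers for stronger inhibition), the lowest of the three numbers measured so far. Compound 1 `Cc1cccc(Cl)c1NC(=O)CN1CCN(c2nnc(Cc3ccncc3)c3ccccc23)CC1` gives 22600 nM in this assay, which lies within the scatter of compound 3, so no order between the two can be claimed. Among the measured compounds shown here, compound 2 `O=C(CN1CCN(c2nnc(Cc3ccccc3)c3ccccc23)CC1)Nc1cccc(F)c1` gives 95000 nM in this assay, and the only step measured in one place, a 4.8-fold lower number from compound 2 to compound 3 (0.68 log units; beyond the scatter), is the sole change at the anilide so far.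

Compound 4 `Cc1cccc(Cl)c1NC(=O)CN1CCN(c2nnc(Cc3ccccc3)c3ccccc23)CC1` has not been measured in this assay. It differs from compound 3 in one place: 2-chloro-6-methylphenyl in place of 2,6-difluorophenyl on an amide-type nitrogen. For the measured compounds named here, no measured step covers this exact exchange. Compound 1 carries the same 2-chloro-6-methylphenyl group on the amide-type nitrogen, and its value of 22600 nM sits beside that of compound 3; the two compounds differ elsewhere, so this is a hint only. The step from compound 3 to compound 4 is therefore expected to stay within the scatter, a 1.1-fold higher number from compound 3 to compound 4 (0.05 log units; within the scatter). Compound 4 is estimated at 22000 nM in this assay, with a range from 8000 nM to 60000 nM.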

Compound 4, half-maximal inhibitory concentration: 53600 nM
Beside the measured number, compound 4's estimate is 2.4-fold (0.39 log units) below it; low and high end bracket the measured number.
By their numbers in this assay, from the lowest: compounds 3 and 1 (each within the scatter of the next); then compounds 4 and 2 (each within the scatter of the next).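

Working notes, continued: in this assay the substituents on the anilide ring are not interchangeable at this position, as the exchange of 2,6-difluorophenyl for 2-chloro-6-methylphenyl gives a 2.7-fold higher number from compound 3 to compound 4 (0.43 log units; beyond the scatter), while the exchange of 3-fluorophenyl for the same group gives a 1.8-fold lower number from compound 2 to compound 4 (0.25 log units; within the scatter). The series also gains its first step away from the anilide, with phenyl in place of pyridin-4-yl giving a 2.4-fold higher number from compound 1 to compound 4 (0.38 log units; beyond the scatter), so with 2-chloro-6-methylphenyl held fixed, that place also shifts the number. No available evidence bears on these steps.

On these data alone, whether pyridin-4-yl gives a similar step alongside 2,6-difluorophenyl remains open. A plain phenyl or a 2,6-dichlorophenyl on the amide-type nitrogen would show how far the anilide step extends beyond these groups.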